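Methylphenyl replaces chlorophenyl on the shared oxadiazole-bearing core

The source may hold more compounds than are shown below. What is called first, only, known or untested is meant among the compounds shown, and "the series" means these compounds.

Measured compounds:
compound 1, `CS(=O)(=O)c1ccc(-c2cnc3[nH]cc(-c4nnc(-c5ccc(F)cc5)o4)c(=O)c3c2)cc1`, 3.78%
compound 2, `CS(=O)(=O)c1ccc(-c2cnc3[nH]cc(-c4nnc(-c5ccccc5)o4)c(=O)c3c2)cc1`, 1.38%
compound 3, `CS(=O)(=O)c1ccc(-c2cnc3[nH]cc(-c4nnc(-c5ccc(Cl)cc5)o4)c(=O)c3c2)cc1`, 0.86%

In a functional assay on MCF7 cells (Homo sapiens) for inhibition, read by MTT assay, with a stated time of 24 h, tested at 5 uM (a lower number here means less inhibition of growth, a higher number more inhibition of growth at the concentration tested), compound 1 gives 3.78%, compound 2 gives 1.38% and compound 3 gives 0.86%. The three compounds differ only in the group on the phenyl ring attached to the five-membered aromatic ring with two nitrogen and one oxygen. The step of a number 2.4 percentage points lower from compound 1 to compound 2 (within the scatter), the step of a number 2.9 percentage points lower from compound 1 to compound 3 (within the scatter) and the step of a number 0.5 percentage points lower from compound 2 to compound 3 (within the scatter) are all within the scatter, so none of the three numbers can be told apart from the others, and compound 3 sits at one end of a narrow spread.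

Compound 4, `Cc1cccc(-c2nnc(-c3c[nH]c4ncc(-c5ccc(S(C)(=O)=O)cc5)cc4c3=O)o2)c1`, is the next step from compound 3: 3-methylphenyl in place of 4-chlorophenyl on an aromatic carbon. Among the compounds with values here, no measured step bears directly on a methyl group on this phenyl ring, but the three measured steps, which exchange hydrogen, fluoro and chloro at the same phenyl ring, were all within the scatter, and every number so far is small. Compound 4 is therefore expected to show no step beyond the scatter, so that a number 1.6 percentage points higher from compound 3 to compound 4 (within the scatter) should be small. For compound 4 the estimate in this assay is 2.5%, with a range from -6% to 12%.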

Compound 4, percent growth inhibition at one concentration: 1.86%
Beside the measured number, compound 4's estimate is 0.6 percentage points above it; the measured number falls inside the stated range.
By their numbers in this assay, from the lowest: compounds 3, 2, 4 and 1 (each within the scatter of the next).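

In this assay, the change to 3-methylphenyl gives a number 1 percentage points higher from compound 3 to compound 4 (within the scatter), and against the other two compounds it gives a number 0.5 percentage points higher from compound 2 to compound 4 (within the scatter) and a number 1.9 percentage points lower from compound 1 to compound 4 (within the scatter). This extends the earlier picture in two ways: a carbon substituent now joins fluoro and chloro on this phenyl ring, and the 3-methylphenyl group, unlike 4-fluorophenyl and 4-chlorophenyl, carries its substituent under a different number in the group's name, yet none of the four compounds can be told apart from the others at the concentration tested. No experimental evidence is available to explain why these changes leave the number within the scatter.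

The compounds shown leave open whether an amine, a carboxylic acid or a longer chain such as butyl on this phenyl ring would give any step beyond the scatter in this assay. With all four numbers small and indistinguishable, they also leave open whether the group at this position matters at all for this read-out, or whether the shared core sets the low level of growth inhibition seen across the set.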